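Swapping Chloro for Fluoro in a Cytotoxicity Test

The source may hold more compounds than are shown below. What is called first, only, known or untested is meant among the compounds shown, and "the series" means these compounds.

Of the compounds shown here, two have been measured in an ADME assay on HOS cells (Homo sapiens) for cytotoxicity, read by a luciferase reporter and ATP content, with a stated time of 48 h; a higher number here means that more compound is tolerated, a lower number that less compound is tolerated. Compound 1 `O=C(NCc1ccc(F)c(F)c1)c1cc2cccnc2n(O)c1=O` gives > 250000 nM, which is a limit of the assay and not a number. Among the measured compounds shown here, compound 2 `O=C(NCc1ccc(F)c(Cl)c1)c1c(O)c2cccnc2n(O)c1=O` gives 102000 nM, the only actual number so far, so it has no numerical neighbour to be ranked against.

The next compound, compound 3 `O=C(NCc1ccc(F)c(F)c1)c1c(O)c2cccnc2n(O)c1=O`, has not yet been measured. It is reached from compound 2 by one small edit, fluoro in place of chloro on an aromatic carbon, turning 3-chloro-4-fluorophenyl into 3,4-difluorophenyl. For the measured compounds named here, no measured pair here shows what this edit does in this assay, so the expectation is modest: little or no change beyond the usual scatter, with a slight lean towards more compound being tolerated. The expected size of this move is a 1.2-fold higher number from compound 2 to compound 3 (0.09 log units; within the scatter). For compound 3 the estimated value is 125000 nM, within an expected range of 60000 nM to 240000 nM.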

Compound 3, half-maximal cytotoxic concentration: 192000 nM
Estimate against measurement, compound 3: 1.5-fold (0.19 log units) below; the range from low to high includes it.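

In this assay, fluoro in place of chloro gives a 1.9-fold higher number from compound 2 to compound 3 (0.27 log units; within the scatter), so this first measured pair shows that turning 3-chloro-4-fluorophenyl into 3,4-difluorophenyl does not shift the result beyond the scatter. The other pair, hydroxy in place of hydrogen on an aromatic carbon, gives an at least 1.3-fold lower number from compound 1 to compound 3 (0.11 log units; that floor lies within the scatter), so this change on the shared core also shows no step beyond the scatter so far. Compound 1 sets one end of that step with a limit and not a number, so the true size of the step stays open: the limit of > 250000 nM in this assay, at which 1 of the 3 values shown sits.

Going by these compounds, what a methoxy group or a nitrile would do in place of the chloro remains open, as does what an amine would do in place of the hydroxy. With so few compounds, neither pair tells whether the same edit would read alike on a different compound.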